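Fluoro for methoxy near the limit of the assay

The source may report more compounds than this note shows. Statements on the series, on what has been measured and on what is new or still open speak of the compounds shown alone.

Compound 1 `COc1ccccc1S(=O)(=O)c1cccc(N)c1C#N`: 146000 nM
Compound 2 `COc1cccc(S(=O)(=O)c2cccc(N)c2C#N)c1`: > 200000 nM, a limit

In a functional assay on MT4 cells (Homo sapiens) for cytotoxicity (a lower number here means a stronger inhibitor, a higher number a weaker inhibitor), compound 2 gives only a limit, > 200000 nM, and not a number. Compound 1 gives a measured 146000 nM, which is also a very high concentration. Compound 3 `N#Cc1c(N)cccc1S(=O)(=O)c1cccc(F)c1` carries one change: fluoro in place of methoxy on an aromatic carbon. No change beyond the usual scatter is expected, though any shift would likely be toward a lower number. The expected change, an at least 1.1-fold lower number from compound 2 to compound 3 (0.07 log units; that floor lies within the scatter), is small. For compound 3 the estimated value is 170000 nM, with an expected range of 70000 nM to 300000 nM.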

Compound 3, half-maximal inhibitory concentration: > 200000 nM
Compound 3: only a limit was reported; the forecaster's own chance of this, stated with the estimate: 45%; middle value at least 1.1-fold (0.07 log units) from the limit.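

Compound 2 and compound 3 each give only a limit and not a number, so no step can be read between them: the limit of > 200000 nM in this assay, at which 2 of the 3 values shown sit.

The compounds shown leave open whether fluoro in place of methoxy on an aromatic carbon changes the result at all, and by how much.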